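From methoxy to hydroxymethyl on a shared core

The source may report more compounds than this note shows. Statements on the series, on what has been measured and on what is new or still open speak of the compounds shown alone.

Among the compounds with values here, in a functional assay on HeLa cells (Homo sapiens) for cytotoxicity, read by neutral red uptake, with a stated time of 3 days (a higher number here means a weaker inhibitor, a lower number a stronger inhibitor), compound 3 (`COc1c(F)c(N)c2c(=O)cc(-c3ccc(N)c(F)c3)oc2c1F`) gives 34000 nM, the only true number among the three compounds measured so far. Compound 1 (`Cc1c(F)c(N)c2c(=O)cc(-c3ccc(N)c(F)c3)oc2c1F`) reaches only a limit, > 100000 nM. Compound 2 (`CCCCc1c(F)c(N)c2c(=O)cc(-c3ccc(N)c(F)c3)oc2c1F`) also reaches only a limit, > 100000 nM.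

The next compound, compound 4 (`Nc1ccc(-c2cc(=O)c3c(N)c(F)c(CO)c(F)c3o2)cc1F`), has the same atoms as compound 3, joined differently: hydroxymethyl in place of methoxy on an aromatic carbon. In short, hydroxymethyl stands in place of methoxy on an aromatic carbon, ortho to two fluoro groups.

Within the data shown here, two measured steps concern this same carbon. One is an at least 2.9-fold lower number from compound 1 to compound 3 (0.46 log units; beyond the scatter), and the other is an at least 2.9-fold lower number from compound 2 to compound 3 (0.46 log units; beyond the scatter). In each, methoxy replaced a group joined to the core through carbon. Hydroxymethyl also joins through carbon, so these steps suggest that the change may partly run in reverse, towards a higher number. However, neither methyl nor butyl carries the hydrogen-bond donor that hydroxymethyl brings, so the comparison is imperfect. In this assay, the expected step is small: a 1.5-fold higher number from compound 3 to compound 4 (0.17 log units; within the scatter). For compound 4, the estimated value is 50000 nM, with an expected range of 18000 nM to 140000 nM.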

Compound 4, half-maximal inhibitory concentration: 24000 nM
Estimate against measurement, compound 4: 2.1-fold (0.32 log units) above; the range from low to high includes it.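

In this assay, rejoining the same atoms so that methoxy becomes hydroxymethyl gives a 1.4-fold lower number from compound 3 to compound 4 (0.15 log units; within the scatter), so the two groups cannot be told apart here, even though hydroxymethyl adds a hydrogen-bond donor. The earlier steps shown here left open whether any group joined through carbon at this aromatic carbon would go with the weak end of the series, and hydroxymethyl shows that it need not: the result is an at least 4.1-fold lower number from compound 1 to compound 4 (0.61 log units; beyond the scatter), and likewise an at least 4.1-fold lower number from compound 2 to compound 4 (0.61 log units; beyond the scatter). Both of these steps give only a minimum size, since compound 1 and compound 2 each stop at a limit and not at a true number: the limit of > 100000 nM in this assay, at which 2 of the 4 values shown sit.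

Compound 3 and compound 4 both carry oxygen at this carbon and the methyl and butyl compounds do not, but two compounds cannot show whether the oxygen itself goes with the lower numbers. As far as these compounds go, an aminomethyl group, a carboxylic acid or a longer chain ending in hydroxy at the same carbon would test this, and it also remains open whether the same order would hold in any cell line other than HeLa.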